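Urea aryl substitution on the shared core: compound 3

This account rests on a few compounds, and the source may have more. Where it says the series, first, only, none or still open, it means among the compounds named here.

Compound 1 `COc1cc(Cl)cc(-c2nn(-c3cccc(NC(=O)Nc4cccc(C(F)(F)F)c4)c3)cc2-c2ccncc2)c1` gives 55% in a functional assay on MOLT-4 cells (Homo sapiens) for inhibition, read by sulforhodamine B assay, with a stated time of 48 h, tested at 0.1 uM (on this read-out higher numbers stand for a weaker effect at the one concentration tested and lower numbers for a stronger effect), and stands at the lower end of the two numbers shown, with compound 2 within the scatter of it. Compound 2 `COc1cc(Cl)cc(-c2nn(-c3cccc(NC(=O)Nc4ccc(Cl)c(C(F)(F)F)c4)c3)cc2-c2ccncc2)c1` gives 57% in this assay, the step of a number 2 percentage points higher from compound 1 to compound 2 (within the scatter) coming with chloro in place of hydrogen on an aromatic carbon. Compound 3 `COc1cc(Cl)cc(-c2nn(-c3cccc(NC(=O)Nc4cc(C(F)(F)F)cc(C(F)(F)F)c4)c3)cc2-c2ccncc2)c1` carries trifluoromethyl in place of hydrogen on an aromatic carbon. Among the compounds with values here, the only step that bears on it, a number 2 percentage points higher from compound 1 to compound 2 (within the scatter), was likewise a single substitution of the same kind and stayed within the scatter, so for compound 3 the expected step of no change at the digits printed from compound 1 to compound 3 (within the scatter) is none beyond the scatter. Compound 3 is estimated at 55%, within 45% to 65%.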

Compound 3, a percentage reported as activity, at one concentration (the size of the read-out at that concentration, not a potency): 87%
Compound 3: the middle estimate sits 32 percentage points below what was measured; measured number outside the range, above it.
By their numbers in this assay, from the lowest: compounds 1 and 2 (each within the scatter of the next); then compound 3.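

In this assay, trifluoromethyl in place of hydrogen on an aromatic carbon, meta to a trifluoromethyl group, gives a number 32 percentage points higher from compound 1 to compound 3 (beyond the scatter), a clear weakening of the effect at the one concentration tested. The earlier chloro change, a number 2 percentage points higher from compound 1 to compound 2 (within the scatter), gave no sign of this, so substitution on this ring is not always silent, although two compounds cannot separate the role of the place from that of the group. No measurement at hand accounts for the weakening. Still open, on these data alone, is whether a methyl group, a chlorine atom or an amine at this same place would match trifluoromethyl or stay close to compound 1.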